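A Bromophenyl Amide Expected to Remain Non-Toxic

The source may hold more compounds than are shown below. What is called first, only, known or untested is meant among the compounds shown, and "the series" means these compounds.

Compound 1 `COc1ccc(-c2cnc(NC(=O)c3ccn[nH]3)n2C)cc1` stands at a limit in a toxicity assay on THP-1 cells (Homo sapiens) for inhibition; on this read-out higher numbers stand for lower toxicity in this test and lower numbers for higher toxicity in this test: compound 1 gives > 100000 nM, which is a limit of the assay and not a number. Compound 2 `COc1ccc(-c2cnc(NC(=O)c3cc(-c4ccccn4)n[nH]3)n2C)cc1`, carrying pyridin-2-yl in place of hydrogen on an aromatic carbon, also returns only a limit, >= 50000 nM. The step that the two limits leave unreadable from compound 1 to compound 2 therefore cannot be read. Compound 3 `Cc1cccc(-c2cnc(NC(=O)c3ccc(F)cc3)n2C)c1` likewise returns a limit, > 100000 nM. Taken together, the limit of > 100000 nM in this assay, at which 2 of the 3 values shown sit, and the limit of >= 50000 nM in this assay, at which 1 of the 3 values shown sits, show that none of the three measured compounds reaches a numeric value in this test.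

The unmeasured compound 4 `COc1ccc(-c2cnc(NC(=O)c3ccc(Br)cc3)n2C)cc1` differs from compound 1 in one place: 4-bromophenyl in place of 1H-pyrazol-5-yl on a carbonyl carbon. For the measured compounds named here, no measured step tracks this change; the one step that exists, between compound 1 and compound 2, is unreadable. Compound 3 shows that a related compound also sits at a limit. The expected step of a number no higher from compound 1 to compound 4 (the limit leaves the size open) is therefore none beyond the scatter, most likely ending again at the limit. Compound 4 is expected to give 100000 nM, between 50000 nM and 200000 nM.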

Compound 4, half-maximal cytotoxic concentration: > 100000 nM
Compound 4: only a limit was reported; the forecaster's own chance of this, stated with the estimate: 80%; the middle value sits exactly at the limit.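

In this assay, for the compounds shown here, compound 4 gives > 100000 nM, a limit of the assay and not a number, and compound 1 also stands at a limit, so no step between them can be read. The compounds shown leave open at what concentration, if any, either compound becomes toxic in this test.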